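Spiro core series: amide side-chain variation and cholesterol transporter binding

This account rests on a few compounds, and the source may have more. Where it says the series, first, only, none or still open, it means among the compounds named here.

Measured compounds:
compound 1 `CC(C)(C)c1ccc(C(=O)N2CCC3(CC2)C(=O)N(CC(=O)NCCCCCNS(C)(=O)=O)CN3c2ccccc2)cc1`: 5500 nM
compound 2 `COC(=O)CCNC(=O)CN1CN(c2ccccc2)C2(CCN(C(=O)c3ccc(C(C)(C)C)cc3)CC2)C1=O`: "not determined" (no result reported)

In an assay on HEK293 cells for displacement of a labelled ligand from NPC1-like intracellular cholesterol transporter 1 (Homo sapiens) (on this read-out higher numbers stand for weaker inhibition and lower numbers for stronger inhibition), compound 1 gives 5500 nM. For compound 2 `COC(=O)CCNC(=O)CN1CN(c2ccccc2)C2(CCN(C(=O)c3ccc(C(C)(C)C)cc3)CC2)C1=O` the this assay entry reads "not determined" (no result reported), so compound 2 stands without a number. Compound 3 `CC(C)(C)c1ccc(C(=O)N2CCC3(CC2)C(=O)N(CC(=O)N2CCCC(C(N)=O)C2)CN3c2ccccc2)cc1` differs from compound 2 by 3-carbamoylpiperidin-1-yl in place of (2-(methoxycarbonyl)ethyl)amino on a carbonyl carbon. Among the compounds with values here, no step between measured compounds exists, so the size of the step to compound 3 cannot be anchored; a change of the amide end within the scatter is expected. Compound 3 is expected to give 5000 nM in this assay, range 1000 nM to 30000 nM.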

Compound 3, half-maximal inhibitory concentration: 16900 nM
Beside the measured number, compound 3's estimate is 3.4-fold (0.53 log units) below it; low and high end bracket the measured number.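

In this assay, within the data shown here, 3-carbamoylpiperidin-1-yl in place of (5-(methanesulfonamido)pentyl)amino on this carbonyl carbon gives a 3.1-fold higher number from compound 1 to compound 3 (0.49 log units; beyond the scatter) and is the first readable step. The group on this carbonyl carbon therefore moves the read-out, with the shared core unchanged. No available data explain the size or direction of this step. Compound 2 has no number, so its step to compound 3 cannot be read. Open, going by these compounds, is how a carboxylic acid, a primary amine or a longer chain on this carbonyl carbon would compare.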